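The source may hold more compounds than are shown below. What is called first, only, known or untested is meant among the compounds shown, and "the series" means these compounds.

Measured so far:
- compound 1 (`Cc1ccc(S(=O)(=O)c2nc3ccccc3nc2Nc2ccccc2)cc1`): 1070 nM
- compound 2 (`COc1ccc(Nc2nc3ccccc3nc2S(=O)(=O)c2ccc(C)cc2)cc1`): > 50000 nM

Both compounds were tested in a functional assay on HCT-116 cells (Homo sapiens) for cytotoxicity, read by MTT assay, with a stated time of 72 h; on this read-out higher numbers stand for weaker inhibition and lower numbers for stronger inhibition. Compound 2 stands at > 50000 nM, which is a limit of the assay and not a number.

Compound 3 (`Cc1ccc(S(=O)(=O)c2nc3ccccc3nc2Nc2ccc(N)cc2)cc1`) carries amino in place of the methoxy of compound 2, on an aromatic carbon para to a large group: amino in place of methoxy on an aromatic carbon.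

Among the compounds with values here, one measured step bears on this change. It is an at least 46-fold higher number from compound 1 to compound 2 (1.66 log units; beyond the scatter), a large step that came with methoxy in place of hydrogen on that same carbon. Compound 3 also loses the methoxy, but amino is not hydrogen, so only part of that step may be reversed. A sizeable move towards lower numbers is therefore expected in this assay. The expected size is an at least 8.3-fold lower number from compound 2 to compound 3 (0.92 log units; beyond the scatter). For compound 3 the estimate is 6000 nM, with an expected range of 1000 nM to 40000 nM.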

Compound 3, half-maximal inhibitory concentration: 11500 nM
For compound 3 the middle estimate is 1.9-fold (0.28 log units) below the measured one; the measured number falls inside the stated range.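

In this assay, amino in place of methoxy on this aromatic carbon gives an at least 4.3-fold lower number from compound 2 to compound 3 (0.63 log units; beyond the scatter), so the identity of the group here matters, not only whether a group is present. Compound 2 stands at > 50000 nM, which is a limit of the assay and not a number, so that step gives only a minimum size: the limit of > 50000 nM in this assay, at which 1 of the 3 values shown sits.

Amino still does not match hydrogen, with an 11-fold higher number from compound 1 to compound 3 (1.03 log units; beyond the scatter), so among these three compounds, both methoxy and amino on this carbon go with higher numbers than hydrogen.

Going by these compounds, what remains open is whether a hydroxyl, a fluorine or a dimethylamino group on this carbon would stay close to hydrogen or follow amino and methoxy. The compounds shown also cannot say why amino and methoxy differ here.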